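The source may hold more compounds than are shown below. What is called first, only, known or untested is meant among the compounds shown, and "the series" means these compounds.

Two compounds of this set have so far been examined in an ADME assay on HEK293 cells (Homo sapiens) for cytotoxicity, read by ATP content, with a stated time of 6 h; on this read-out higher numbers stand for lower toxicity in this test and lower numbers for higher toxicity in this test. Compound 1 `CCCCNc1nc(N)nc2ccn(Cc3ncccc3OC)c12` is one of them; in this assay compound 1 gives > 24000 nM, which is a limit of the assay rather than a number. Compound 2 `Cc1ccc(CNc2nc(N)nc3ccn(Cc4ccccn4)c23)nc1` is the other; in this assay compound 2 gives > 24000 nM, again a limit of the assay and not a measured number. Compound 2 thus stands where every value shown stands, at the limit of > 24000 nM in this assay, at which 2 of the 2 values shown sit, and two limits allow no ordering between compound 1 and compound 2.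

Compound 3 `Cc1cc(CNc2nc(N)nc3ccn(Cc4ccccn4)c23)no1` has not yet been measured in this assay. It differs from compound 2 in one place (5-methyl-1,2-oxazol-3-yl in place of 5-methylpyridin-2-yl on a saturated chain carbon bound to a nitrogen on an aromatic ring). Within the data shown here, no step between measured compounds is available to show how a change of this kind moves the half-maximal cytotoxic concentration, so the expectation rests on the position of compound 2 alone. The expected step is a step that the limit leaves unreadable from compound 2 to compound 3, none beyond the usual scatter. For compound 3 the estimate in this assay is 30000 nM, within a range from 12000 nM to 75000 nM, and the assay is expected most likely to report only a limit again.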

Compound 3, half-maximal cytotoxic concentration: > 24000 nM
Compound 3: no number, only a limit; the forecaster's own chance of this, stated with the estimate: 80%; the middle value does not contradict the limit.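

Compound 2 and compound 3 both give only a limit in this assay, so no step can be read between them: the limit of > 24000 nM in this assay, at which 3 of the 3 values shown sit.

The compounds shown leave open whether compound 2 and compound 3 differ at all in this assay, and at what concentration any of compounds 1, 2 and 3 would reach a measurable half-maximal cytotoxic concentration.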